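Chloro-to-fluoro swaps on a benzylic sulfone series

The source may hold more compounds than are shown below. What is called first, only, known or untested is meant among the compounds shown, and "the series" means these compounds.

Measured compounds:
compound 1 `CCOC(=O)C1=CCCCC1S(=O)(=O)Cc1ccc(Cl)cc1F`: 104 nM
compound 2 `CCOC(=O)C1=CCCCC1S(=O)(=O)Cc1ccc(F)cc1F`: 14 nM
compound 3 `CCOC(=O)C1=CCCCC1S(=O)(=O)Cc1cccc(Cl)c1F`: 12 nM

In a functional assay on RAW264.7 cells (Mus musculus), read by fluorescence (a lower number here means a stronger inhibitor, a higher number a weaker inhibitor), compound 1 gives 104 nM. Compound 2 differs by fluoro in place of chloro on an aromatic carbon, and the step of a 7.4-fold lower number from compound 1 to compound 2 (0.87 log units; beyond the scatter). Compound 3 gives 12 nM; the difference between its core and that of compound 1 is not broken down here. Compound 4 `CCOC(=O)C1=CCCCC1S(=O)(=O)Cc1cccc(F)c1F` is not yet measured; it differs from compound 3 by fluoro in place of chloro on an aromatic carbon. This is the same kind of change as from compound 1 to compound 2, but the place differs: there the changed carbon was meta to a fluoro group and para to a large group, here it is ortho to a fluoro group and meta to a large group. Because a 7.4-fold lower number from compound 1 to compound 2 (0.87 log units; beyond the scatter), the expected step of a 1.5-fold lower number from compound 3 to compound 4 (0.18 log units; within the scatter) is smaller, since compound 3 already gives 12 nM. Compound 4 is estimated at 8 nM, expected between 3 nM and 25 nM.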

Compound 4, half-maximal inhibitory concentration: 100 nM
Beside the measured number, compound 4's estimate is 13-fold (1.10 log units) below it, and the stated range ends below it.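

In this assay, replacing chloro with fluoro does not repeat the earlier result, and the new step is an 8.3-fold higher number from compound 3 to compound 4 (0.92 log units; beyond the scatter). Set beside the earlier step, the same swap moves the number in opposite directions on the two cores, by more than ordinary scatter: the same change on two cores in this assay, a 7.4-fold lower number (0.87 log units; beyond the scatter) from compound 1 to compound 2 and an 8.3-fold higher number (0.92 log units; beyond the scatter) from compound 3 to compound 4, 62-fold (1.79 log units) apart, beyond the scatter of two such steps. This shows that the effect of the swap cannot be carried from one core to another in this series, but two pairs of compounds do not show why the direction differs or what the swap would do at any other place.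

The changed carbon carries only chloro or fluoro in the compounds shown, so the effect of a methyl or methoxy group there remains open. Also open, on these data alone, is how either core would respond with a carboxylic acid in place of the ethyl ester.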